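Lengthening the Side Chain by One Carbon

The source may report more compounds than this note shows. Statements on the series, on what has been measured and on what is new or still open speak of the compounds shown alone.

Measured so far in a functional assay on A549 cells (Homo sapiens) for antiproliferative activity, read by MTT assay, with a stated time of 72 h; on this read-out lower numbers stand for stronger inhibition and higher numbers for weaker inhibition:
- compound 1 `CCC/C=C/C(=O)Nc1cc2c(N3CCc4ccccc43)ncnc2cc1OC`: 2920 nM
- compound 2 `C/C=C/C(=O)Nc1cc2c(N3CCCc4ccccc43)ncnc2cc1OC`: 8190 nM
- compound 3 `CC/C=C/C(=O)Nc1cc2c(N3CCCc4ccccc43)ncnc2cc1OC`: 5030 nM

At 5030 nM, compound 3 lies within the usual scatter of both other compounds, so it cannot be separated from either. The next compound, compound 4 `CCC/C=C/C(=O)Nc1cc2c(N3CCCc4ccccc43)ncnc2cc1OC`, extends the chain of compound 3 from but-1-en-1-yl to pent-1-en-1-yl: methyl in place of hydrogen on a saturated chain carbon, two bonds along the chain from a double-bonded chain carbon.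

One measured step is the closest parallel. It also adds methyl in place of hydrogen, but on a saturated chain carbon bound to a double-bonded chain carbon: a 1.6-fold lower number from compound 2 to compound 3 (0.21 log units; within the scatter). That step stays within the scatter. Compound 1 carries the pent-1-en-1-yl chain on a different core and gives 2920 nM, which is within the scatter of the value of compound 3.

Together these suggest no step beyond the scatter in this assay, with at most a slight drift towards a lower number. The estimated step is a 1.3-fold lower number from compound 3 to compound 4 (0.10 log units; within the scatter). The expected value for compound 4 is 4000 nM, with an estimated range of 2000 nM to 8000 nM.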

Compound 4, half-maximal inhibitory concentration: 1800 nM
For compound 4 the middle estimate is 2.2-fold (0.35 log units) above the measured one; measured number outside the range, below it.
By their numbers in this assay, from the lowest: compounds 4, 1, 3 and 2 (each within the scatter of the next, the first and the last beyond it).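

In this assay, among these compounds, the step at this carbon is the first chain extension here to clear the scatter (a 2.8-fold lower number from compound 3 to compound 4 (0.45 log units; beyond the scatter)), whereas the previous single added methyl did not. Taken together, the two additions give a larger change across the short series of chains (a 4.6-fold lower number from compound 2 to compound 4 (0.66 log units; beyond the scatter)). With the pent-1-en-1-yl chain on both, 1,2,3,4-tetrahydroquinolin-1-yl in place of 2,3-dihydro-1H-indol-1-yl gives a step that stays within the scatter (a 1.6-fold lower number from compound 1 to compound 4 (0.21 log units; within the scatter)), so the two cannot be told apart at this chain length.

These compounds leave open whether a longer chain, such as hex-1-en-1-yl, would extend the change or whether an amine at the end of the chain would be tolerated. Nothing available here explains why one more carbon at this position goes with the lower number.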